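This account rests on a few compounds, and the source may have more. Where it says the series, first, only, none or still open, it means among the compounds named here.

Values measured so far (a functional assay on CCRF-CEM cells (Homo sapiens) for inhibition, read by MTT assay, with a stated time of 72 h; a lower number here means a stronger inhibitor, a higher number a weaker inhibitor):
- compound 1 `COc1cc(NC(C)CCCNC(=O)Nc2cccc(F)c2)c2ncccc2c1` gives 21000 nM
- compound 2 `COc1cc(NC(C)CCCNC(=O)Nc2cccc(Cl)c2)c2ncccc2c1` gives 22000 nM
- compound 3 `COc1cc(NC(C)CCCNC(=O)Nc2ccc(C(F)(F)F)cc2)c2ncccc2c1` gives 14000 nM

Compound 3 does not stand apart from the other two, since its steps to both lie within the scatter. Compound 4 `COc1cc(NC(C)CCCNC(=O)NNC(=O)Nc2ccc(O)cc2)c2ncccc2c1` has not yet been measured. It keeps the shared core and chain of compound 3, but ((4-hydroxyphenyl)carbamoyl)amino replaces 4-(trifluoromethyl)phenyl on an amide-type nitrogen whose other neighbour is a carbonyl carbon (((4-hydroxyphenyl)carbamoyl)amino in place of 4-(trifluoromethyl)phenyl on an amide-type nitrogen).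

The closest evidence comes from earlier exchanges at that same nitrogen. Placing 4-(trifluoromethyl)phenyl there instead of 3-fluorophenyl gave a small step (a 1.5-fold lower number from compound 1 to compound 3 (0.18 log units; within the scatter)), and placing it there instead of 3-chlorophenyl gave another (a 1.6-fold lower number from compound 2 to compound 3 (0.20 log units; within the scatter)). Chloro in place of fluoro made almost no difference (a 1.0-fold higher number from compound 1 to compound 2 (0.02 log units; within the scatter)). All three steps lie within the scatter. However, none of the measured compounds carries the entering group, so they guide this larger change only loosely and favour no direction. No step beyond the scatter is therefore expected, though with wide uncertainty.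

The expected step is small (a 1.4-fold higher number from compound 3 to compound 4 (0.15 log units; within the scatter)). The estimate for compound 4 is 20000 nM (expected range 6000 nM to 60000 nM).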

Compound 4, half-maximal inhibitory concentration: 111000 nM
The estimate for compound 4 lay 5.6-fold (0.74 log units) below the measured number, outside the stated range (above it).
By their numbers in this assay, from the lowest: compounds 3, 1 and 2 (each within the scatter of the next); then compound 4.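

Among compounds 1, 2 and 3, exchanging one substituted phenyl for another on this amide-type nitrogen left the number in this assay within the scatter, so those compounds gave no sign that the position was sensitive to change. The ((4-hydroxyphenyl)carbamoyl)amino group is the only one shown that goes beyond the scatter, and it gives a weaker inhibitor than all three phenyl-bearing compounds (a 7.9-fold higher number from compound 3 to compound 4 (0.90 log units; beyond the scatter)), (a 5.0-fold higher number from compound 2 to compound 4 (0.70 log units; beyond the scatter)) and (a 5.3-fold higher number from compound 1 to compound 4 (0.72 log units; beyond the scatter)), so this position does respond to a large enough change, though the steps are modest. No measurement shown gives a reason for this weakening.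

The entering group differs from the phenyl groups in more than one way at once, with an added carbamoylamino link and a hydroxyl on the ring, and the compounds shown cannot say which of these parts goes with the weaker number. A 4-hydroxyphenyl placed directly on this nitrogen, or a ((4-(trifluoromethyl)phenyl)carbamoyl)amino group in the same place, would pull the two parts apart.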